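Swapping the nitrofuran for a nitrophenyl in compound 4

The source may report more compounds than this note shows. Statements on the series, on what has been measured and on what is new or still open speak of the compounds shown alone.

Compound 2 `CC1(C)CCN(S(=O)(=O)c2ccc(NC(=O)c3ccc([N+](=O)[O-])o3)cc2)CC1` was tested in an ADME assay on IMR-90 cells (Homo sapiens) for cytotoxicity, read by CellTiter-Blue, with a stated time of 46 h; a higher number here means that more compound is needed for the effect, a lower number that less compound is needed. In this assay compound 2 gives only a limit, > 25000 nM. Compound 1 `CC1CCN(S(=O)(=O)c2ccc(NC(=O)c3ccc([N+](=O)[O-])o3)cc2)CC1` likewise gives only a limit in this assay, > 25000 nM. Compound 3 `O=C(Nc1ccc(S(=O)(=O)N2CCC(F)CC2)cc1)c1ccc([N+](=O)[O-])o1` also gives only a limit, > 25000 nM. All three values sit at the same limit (the limit of > 25000 nM in this assay, at which 3 of the 3 values shown sit), so the steps a step that the two limits leave unreadable from compound 1 to compound 2, a step that the two limits leave unreadable from compound 1 to compound 3 and a step that the two limits leave unreadable from compound 2 to compound 3 cannot be sized. Compound 4 `CC1(C)CCN(S(=O)(=O)c2ccc(NC(=O)c3cccc([N+](=O)[O-])c3)cc2)CC1` differs from compound 2 at the carbonyl carbon: 3-nitrophenyl in place of 5-nitrofuran-2-yl on a carbonyl carbon. Within the data shown here, no measured step touches this position, and no measured compound gives a number to build on. Compound 4 is therefore expected to stay at the limit as well, a step that the limit leaves unreadable from compound 2 to compound 4. The estimate for compound 4 is 30000 nM, between 8000 nM and 120000 nM.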

Compound 4, half-maximal effective concentration: > 25000 nM
Compound 4: no number, only a limit (the forecaster's own chance of this, stated with the estimate: 80%); the middle value is on the limit's open side.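

Compound 2 and compound 4 both give only a limit in this assay, so the step between them cannot be read: the limit of > 25000 nM in this assay, at which 4 of the 4 values shown sit. As far as these compounds go, whether 3-nitrophenyl in place of 5-nitrofuran-2-yl changes the cytotoxicity at all stays open.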